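The source may hold more compounds than are shown below. What is called first, only, known or untested is meant among the compounds shown, and "the series" means these compounds.

In a functional assay on HepG2 cells (Homo sapiens) for antiproliferative activity, read by CCK-8 assay, with a stated time of 48 h (a higher number here means a weaker inhibitor, a lower number a stronger inhibitor), three compounds on a shared core have been read. Compound 1 `COc1ccc(/C=C\c2cc(OC)c(OC)c(OC)c2)cc1OCc1ccc(CN2C[C@H](O)C[C@@H]2C(=O)O)cc1` gives > 10000 nM, which is a limit of the assay and not a number. Compound 2 `COc1ccc(/C=C\c2cc(OC)c(OC)c(OC)c2)cc1OCc1ccc(CN2CCCC[C@H]2C(=O)O)cc1` gives > 10000 nM, again a limit. For the measured compounds named here, compound 3 `COc1ccc(/C=C\c2cc(OC)c(OC)c(OC)c2)cc1OCc1ccc(CNCCO)cc1` gives 5900 nM, the only actual number in the set. The remaining readings therefore stand at the limit of > 10000 nM in this assay, at which 2 of the 3 values shown sit.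

Compound 4 `COc1ccc(/C=C\c2cc(OC)c(OC)c(OC)c2)cc1OCc1ccc(CN2CC[C@H](O)C2)cc1` differs from compound 3 at a single place: 3-hydroxypyrrolidin-1-yl in place of (2-hydroxyethyl)amino on a saturated chain carbon bound to an aromatic carbon. In words, 3-hydroxypyrrolidin-1-yl takes the place of (2-hydroxyethyl)amino on a saturated chain carbon bound to an aromatic carbon.

Going by the values given here, two measured steps bear on this change, an at least 1.6-fold lower number from compound 1 to compound 3 (0.22 log units; that floor lies within the scatter) and an at least 1.6-fold lower number from compound 2 to compound 3 (0.22 log units; that floor lies within the scatter). Both give only a floor, and neither shows what a 3-hydroxypyrrolidin-1-yl group does in this assay. No step beyond the scatter is therefore expected, and the estimate stays close to compound 3 at 5900 nM. The expected change is a 1.0-fold higher number from compound 3 to compound 4 (0.01 log units; within the scatter). Compound 4 is expected at 6000 nM, with an estimated range of 2000 nM to 14000 nM.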

Compound 4, half-maximal inhibitory concentration: 6600 nM
Compound 4: middle estimate off by 1.1-fold (0.04 log units), on the low side, within the range that was stated.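

In this assay, for the compounds shown here, this change gives the first step at this position with a number at both ends: a 1.1-fold higher number from compound 3 to compound 4 (0.05 log units; within the scatter). Closing the open (2-hydroxyethyl)amino into the five-membered ring of 3-hydroxypyrrolidin-1-yl thus leaves the reading within the scatter, and the same holds for the added defined stereocentre. The comparisons with the two carboxy-bearing compounds give only floors, an at least 1.5-fold lower number from compound 2 to compound 4 (0.18 log units; that floor lies within the scatter) and an at least 1.5-fold lower number from compound 1 to compound 4 (0.18 log units; that floor lies within the scatter), since compound 1 and compound 2 each stand at a limit and not at a number: the limit of > 10000 nM in this assay, at which 2 of the 4 values shown sit.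

The compounds shown leave open how a pyrrolidin-1-yl group without the hydroxyl, or a longer chain such as (3-hydroxypropyl)amino, would read in this assay. As far as these compounds go, it also stays open whether a carboxylic acid added to the 3-hydroxypyrrolidin-1-yl ring would by itself carry a compound to the limit.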